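Difluorophenyl in Place of Pyridyl on a Shared Core

A few compounds are considered here, and "the series" means these few. Any claim that something is new, unique, unknown or untested is made for them only; others in the source may bear on it.

Compound 1 `C[C@H](Nc1ncnc2[nH]cnc12)c1nn(-c2ccncc2)c2cc(F)ccc12` was tested in a functional assay on Hep 3B2 cells (Homo sapiens) for inhibition, read by sulforhodamine B assay, with a stated time of 72 h, tested at 10 uM (on this read-out higher numbers stand for more inhibition at the one concentration tested (going by the name of the read-out) and lower numbers for less inhibition), and gave 5%. Compound 2 `C[C@H](Nc1ncnc2[nH]cnc12)c1nn(-c2cccnc2)c2ccc(F)cc12`, built on the same core, in this assay gave 13%; these two numbers lie within the usual scatter of each other, so compound 1 cannot be set apart from compound 2 on this read-out. Neither compound shows much inhibition at the single concentration tested. Compound 3 `C[C@H](Nc1ncnc2[nH]cnc12)c1nn(-c2cc(F)cc(F)c2)c2cc(F)ccc12` differs from compound 1 in one place: 3,5-difluorophenyl in place of pyridin-4-yl on an aromatic nitrogen. For the measured compounds named here, no measured pair in this set shows the effect of such a change, so the expectation rests only on the low numbers of compound 1 and compound 2. The step is expected to be small, a number 5 percentage points higher from compound 1 to compound 3 (within the scatter), and not clearly beyond the scatter in either direction. Compound 3 is therefore estimated to give about 10% in this assay, within a range from 0% to 30%.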

Compound 3, a percentage reported as inhibition, at one concentration (the size of the read-out at that concentration, not a potency): 14%
Estimate against measurement, compound 3: 4 percentage points below; the measured number falls inside the stated range.
By their numbers in this assay, from the lowest: compounds 1, 2 and 3 (each within the scatter of the next).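

For the compounds shown here, with 3,5-difluorophenyl in place of pyridin-4-yl on the aromatic nitrogen, this assay gives the first direct reading at this position: a number 9 percentage points higher from compound 1 to compound 3 (within the scatter). On this read-out, a six-membered aromatic ring of carbon only, carrying fluorine, therefore cannot be told apart from the ring with a hetero atom, and compound 3, at 14%, still shows little inhibition at the single concentration tested. No accompanying measurement offers an explanation for this result.

On these data alone, it stays open whether an amine or a carboxylic acid on this ring, or a longer chain in its place on the aromatic nitrogen, would move the number beyond the scatter. Compound 2 differs from compound 1 in more than one place, so the separate contributions of its pyridine ring and its fluorine on the shared core cannot be read.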